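Notes on the step from compound 3 to compound 4

The compounds below may be only part of what the source reports. "The series", "measured", "known", "first", "only" and "open" are said of these compounds alone.

In a functional assay on EC9706 cells (Homo sapiens) for antiproliferative activity, read by MTT assay, with a stated time of 72 h (a higher number here means a weaker inhibitor, a lower number a stronger inhibitor), compound 1 `C/C(=N\NC(=O)c1cccc(S(=O)(=O)N2CCOCC2)c1)c1cc(O)ccc1O` gives 3510 nM, and compound 2 `C/C(=N\NC(=O)c1cccc(S(=O)(=O)N2CCOCC2)c1)c1cc(Br)ccc1O` gives 24700 nM. Bromo in place of hydroxy on an aromatic carbon accounts for the difference between them: a 7.0-fold higher number from compound 1 to compound 2 (0.85 log units; beyond the scatter), a modest step beyond the scatter.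

Compound 3 `O=C(N/N=C/c1ccco1)c1cccc(S(=O)(=O)N2CCOCC2)c1` gives > 100000 nM, which is a limit of the assay and not a number. Compound 3 thus sits at the limit of > 100000 nM in this assay, at which 1 of the 3 values shown sits.

Compound 4 `O=C(N/N=C/c1cc(Cl)ccc1O)c1cccc(S(=O)(=O)N2CCOCC2)c1` differs from compound 3 by 5-chloro-2-hydroxyphenyl in place of furan-2-yl on a carbon with a double bond to nitrogen. In words, 5-chloro-2-hydroxyphenyl stands in place of furan-2-yl on a carbon with a double bond to nitrogen.

Going by the values given here, no measured step covers this exchange directly. The only one that bears on it is the modest step already noted, a 7.0-fold higher number from compound 1 to compound 2 (0.85 log units; beyond the scatter), which concerns a substituent on an aromatic carbon. The closest anchor for compound 4 is therefore compound 2 at 24700 nM, a measured number.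

The expected step in this assay is an at least 5.0-fold lower number from compound 3 to compound 4 (0.69 log units; beyond the scatter), towards a lower number. Its size stays loose, as the starting point is only a limit. For compound 4 the estimated value is 20000 nM, with an expected range of 5000 nM to 80000 nM.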

Compound 4, half-maximal inhibitory concentration: 2150 nM
Beside the measured number, compound 4's estimate is 9.3-fold (0.97 log units) above it; measured number below the stated range.
By their numbers in this assay, from the lowest: compounds 4 and 1 (each within the scatter of the next); then compound 2. At a limit, above all of these: compound 3.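

At the carbon with a double bond to nitrogen, in this assay, replacing furan-2-yl with 5-chloro-2-hydroxyphenyl gives an at least 46-fold lower number from compound 3 to compound 4 (1.66 log units; beyond the scatter). This is the only step shown at this place, and it is large, whereas the earlier step between compound 1 and compound 2 concerned only a substituent on an aromatic carbon. The size of the new step has a floor and no fixed value, and compound 3 stands at a limit of the assay, not at a number: the limit of > 100000 nM in this assay, at which 1 of the 4 values shown sits.

The exchange alters the ring, the chlorine and the hydroxy group in a single move, so the compounds shown do not assign the step to any one of these, and a plain phenyl group at the same place would be needed to begin separating them. It also remains open how the 5-chloro-2-hydroxyphenyl group would respond if an amine or a carboxylic acid stood in place of the chlorine, as no step shown covers either exchange.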